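Chloro-methyl phenyl variant of a fatty acid receptor agonist

The source may report more compounds than this note shows. Statements on the series, on what has been measured and on what is new or still open speak of the compounds shown alone.

Compound 1 `Cc1ccccc1-c1cccc(COc2ccc([C@H](CC(=O)O)c3nccn3C)cc2)c1` gives 89000 nM in an assay on CHO cells for agonist activity at Free fatty acid receptor 1 (Homo sapiens), read by luminescence, with a stated time of 20 s, in the presence of a further agent that is not named here; on this read-out lower numbers stand for an effect already at smaller amounts and higher numbers for an effect only at larger amounts of compound.
Compound 2 `CCc1ccccc1-c1cccc(COc2ccc([C@H](CC(=O)O)c3nccn3C)cc2)c1` gives 65000 nM in this assay.
Compound 3 `Cn1ccnc1[C@@H](CC(=O)O)c1ccc(OCc2cccc(-c3ccccc3S(C)(=O)=O)c2)cc1` gives "not determined" (no result reported) in this assay.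

Compound 3 therefore stands nowhere on the numbers: it has no result in this assay. The step to compound 4 `Cc1c(Cl)cccc1-c1cccc(COc2ccc([C@H](CC(=O)O)c3nccn3C)cc2)c1` replaces (3-chloro-2-methylphenyl in place of 2-(methylsulfonyl)phenyl on an aromatic carbon). Among the measured compounds shown here, no measured step touches compound 3 or compound 4 directly. For the measured compounds named here, the only measured step, a 1.4-fold lower number from compound 1 to compound 2 (0.14 log units; within the scatter), exchanges methyl for ethyl on the same group and stays within the scatter, and both compound 1 and compound 2 give high numbers in this assay. Going by the values given here, compound 4 shares the methyl of compound 1 on that group and adds a chlorine, a change for which no measured step exists here. The expectation for compound 4 therefore rests on compound 1 and compound 2 alone: a number in the same high region, with no step beyond the scatter foreseen in this assay. Compound 4 is estimated at 70000 nM, expected to fall between 20000 nM and 250000 nM.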

Compound 4, half-maximal effective concentration: 22000 nM
For compound 4 the middle estimate is 3.2-fold (0.50 log units) above the measured one, and the stated range covers the measured number.
By their numbers in this assay, from the lowest: compound 4; then compounds 2 and 1 (each within the scatter of the next).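

In this assay, swapping methyl for ethyl had moved the number only within the scatter, so this ring had not yet shown a clear response to a change. Adding a chlorine to the methyl-bearing ring gives the first change beyond the scatter, a modest one: a 4.0-fold lower number from compound 1 to compound 4 (0.61 log units; beyond the scatter), and the comparison with the ethyl compound points the same way with a 3.0-fold lower number from compound 2 to compound 4 (0.47 log units; beyond the scatter). Compound 3 has no number, so its step to compound 4 cannot be read, and nothing available here explains the effect of the chlorine.

From the compounds shown here alone, it remains open whether a fluorine, a bromine or a methoxy group in place of the chlorine would have a similar effect. Also open, going by these compounds, is whether a chlorine would give a similar step alongside the ethyl group of compound 2.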